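Linker extension notes on a hydroxamate series

The compounds below may be only part of what the source reports. "The series", "measured", "known", "first", "only" and "open" are said of these compounds alone.

Compound 1 `Cc1nc2c(c(N(C)c3ccc(OCCCC(=O)NO)cc3)n1)CCC2` and compound 2 `Cc1nc2c(c(N(C)c3ccc(OCCCCCC(=O)NO)cc3)n1)CCC2` share one core and differ only in the arm that carries the hydroxamic acid. In an assay on isolated protein for inhibition of protein deacetylase HDAC6 (Homo sapiens), read by fluorescence, with a stated time of 1 h (on this read-out lower numbers stand for stronger inhibition and higher numbers for weaker inhibition), compound 1 gives 40 nM. In the same this assay compound 2 gives 20 nM. The change between the two is 2-(hydroxycarbamoyl)ethyl in place of hydroxycarbamoyl on a saturated chain carbon, three bonds along the chain from an oxygen on an aromatic ring and it made a 2.0-fold lower number from compound 1 to compound 2 (0.30 log units; within the scatter).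

Compound 3 `Cc1nc(N(C)c2cccc(OCC(=O)NO)c2)c2ccccc2n1` has another core; the difference between the two cores is not broken down here. In this assay compound 3 reaches only the limit (the limit of > 1000 nM in this assay, at which 1 of the 3 values shown sits), reported as > 1000 nM, which is a boundary of the measurement and not a number.

Compound 4 `Cc1nc(N(C)c2cccc(OCCCC(=O)NO)c2)c2ccccc2n1` has not yet been measured. It differs from compound 3 by 2-(hydroxycarbamoyl)ethyl in place of hydroxycarbamoyl on a saturated chain carbon bound to an oxygen on an aromatic ring. Going by the values given here, this is the same kind of change as the one from compound 1 to compound 2, not the same: there the place was a saturated chain carbon three bonds along the chain from an oxygen on an aromatic ring, here it is a saturated chain carbon bound to an oxygen on an aromatic ring. Since compound 3 sits at a limit, the earlier step cannot be carried over directly. The arm of compound 4 has the same length as the arm of compound 1, which gives 40 nM in this assay, and the expectation rests on that, tempered by the different core. Compound 4 is expected to give about 150 nM in this assay, within 30 nM to 1000 nM. For compound 4 this means an expected step of an at least 6.6-fold lower number from compound 3 to compound 4 (0.82 log units; beyond the scatter).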

Compound 4, half-maximal inhibitory concentration: > 1000 nM
Compound 4: a limit, no number; the forecaster's own chance of this, stated with the estimate: 20%; middle value at least 6.6-fold (0.82 log units) away from the limit.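

Compound 3 and compound 4 both stop at the limit of this assay, so no step can be read between them, and both entries are limits, not numbers: the limit of > 1000 nM in this assay, at which 2 of the 4 values shown sit.

As far as these compounds go, what stays open is whether 3-(hydroxycarbamoyl)propoxy in place of (hydroxycarbamoyl)methoxy changes inhibition at all on the core of compound 3, and how far past the limit either compound lies.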